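The source may hold more compounds than are shown below. What is called first, only, known or untested is meant among the compounds shown, and "the series" means these compounds.

Compound 2 `COc1ccccc1-c1nnc(-c2ccc(C(=O)N/N=C/c3ccc(O)c(O)c3)cc2)o1` gives the lowest number of the three measured compounds in an ADME assay on THP-1 cells (Homo sapiens) for cytotoxicity (a higher number here means a weaker inhibitor, a lower number a stronger inhibitor), at 100000 nM. Compound 1 `COc1ccccc1-c1nnc(-c2ccc(C(=O)N/N=C/c3cccc(F)c3)cc2)o1` gives 353000 nM in this assay, and compound 3 `COc1ccc(O)c(/C=N/NC(=O)c2ccc(-c3nnc(-c4ccccc4OC)o3)cc2)c1` gives 303000 nM. Both steps away from compound 2 are beyond the scatter: a 3.5-fold lower number from compound 1 to compound 2 (0.55 log units; beyond the scatter) and a 3.0-fold higher number from compound 2 to compound 3 (0.48 log units; beyond the scatter).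

Compound 4 `COc1ccccc1-c1nnc(-c2ccc(C(=O)N/N=C/c3ccc(O)cc3)cc2)o1` differs from compound 2 in one place: hydrogen in place of hydroxy on an aromatic carbon. The change trims the 3,4-dihydroxyphenyl to a 4-hydroxyphenyl, leaving a single hydroxy on that ring.

Within the data shown here, the two measured steps that bear on this both run between compound 2 and a ring with a different substitution pattern, and both were modest in size; no measured pair shows the loss of one hydroxy alone. Since the 3,4-dihydroxyphenyl compound stands lowest, removing one of its hydroxy groups is expected to move the number back toward the other two, so a modest rise in this assay is expected, with an estimated step of a 2.5-fold higher number from compound 2 to compound 4 (0.40 log units; beyond the scatter). Compound 4 is therefore estimated at 250000 nM, with a range from 100000 nM to 550000 nM.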

Compound 4, half-maximal inhibitory concentration: 261000 nM
For compound 4 the middle estimate is 1.0-fold (0.02 log units) below the measured one; low and high end bracket the measured number.
By their numbers in this assay, from the lowest: compound 2; then compounds 4, 3 and 1 (each within the scatter of the next).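

Among these compounds, measured in this assay, the hydroxy ortho to a hydroxy group proves to matter on its own, with hydrogen in its place giving a 2.6-fold higher number from compound 2 to compound 4 (0.42 log units; beyond the scatter) as the first step that changes this one group alone. Among the compounds shown here, the remaining 4-hydroxyphenyl no longer sets its compound apart: there is a 1.2-fold lower number from compound 3 to compound 4 (0.06 log units; within the scatter) and also a 1.4-fold lower number from compound 1 to compound 4 (0.13 log units; within the scatter) and both lie within the scatter. Among these four compounds, then, only the 3,4-dihydroxyphenyl gives a number apart from the rest, and a single hydroxy on the ring does not reproduce it in compound 3 or compound 4.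

As far as these compounds go, whether an amine or a carboxylic acid on that aromatic carbon would hold the number of compound 2 stays open. Nothing given here accounts for the step.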